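Replacing a hydroxyphenyl with a dichlorophenyl on the shared core

The source may hold more compounds than are shown below. What is called first, only, known or untested is meant among the compounds shown, and "the series" means these compounds.

Compound 1 `CCCS(=O)(=O)Nc1ccc(F)c(C(=O)c2n[nH]c3ncc(-c4ccccc4O)cc23)c1F` gives 9% in an assay for binding affinity to dual specificity mitogen-activated protein kinase kinase 4 (Homo sapiens), read by KINOMEscan, tested at 100 nM; a lower number here means a stronger effect, a higher number a weaker effect of the compound at the concentration tested.
Compound 2 `CCCS(=O)(=O)Nc1ccc(F)c(C(=O)c2n[nH]c3ncc(-c4ccc(O)cc4)cc23)c1F` gives 0.75% in this assay.

Compound 2 has the lowest of the two numbers in this assay; its nearest neighbour is compound 1, and the step of a number 8.3 percentage points lower from compound 1 to compound 2 (within the scatter) lies within the scatter, so the two cannot be told apart.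

Compound 3 `CCCS(=O)(=O)Nc1ccc(F)c(C(=O)c2n[nH]c3ncc(-c4ccc(Cl)c(Cl)c4)cc23)c1F` has not yet been measured in this assay. It differs from compound 2 by 3,4-dichlorophenyl in place of 4-hydroxyphenyl on an aromatic carbon. Among the compounds with values here, the only measured step, from compound 1 to compound 2, moves a hydroxyl group from one place on the ring to another and does not remove it, so no measured step bears directly on this change. The expectation therefore rests on weak ground. Compound 3 is expected to give about 12% in this assay, with a range from 0.5% to 55%. The step of a number 11.3 percentage points higher from compound 2 to compound 3 (beyond the scatter) is thus estimated as a modest rise, a somewhat weaker effect.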

Compound 3, a percentage reported as activity, at one concentration (the size of the read-out at that concentration, not a potency): 45%
Compound 3: the middle estimate sits 33 percentage points below what was measured; measured number inside the range.
By their numbers in this assay, from the lowest: compounds 2 and 1 (each within the scatter of the next); then compound 3.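

In this assay, this position on the shared core proves sensitive to the group it carries: 3,4-dichlorophenyl gives a number 44.3 percentage points higher from compound 2 to compound 3 (beyond the scatter) and a number 36 percentage points higher from compound 1 to compound 3 (beyond the scatter), a clearly weaker effect at the concentration tested. Moving the hydroxyl around the ring had given no step beyond the scatter, so the change of substituents shows what that move could not. This single swap removes the hydroxyl, with its hydrogen-bond donor and acceptor, and adds two chlorines, and no available evidence explains the rise.

Still open, going by these compounds, is whether losing the hydroxyl or gaining the chlorines accounts for the step. An unsubstituted phenyl, or a phenyl carrying an amine or a single chlorine, would help separate the two.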